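This account rests on a few compounds, and the source may have more. Where it says the series, first, only, none or still open, it means among the compounds named here.

Measured compounds:
compound 1, `O=C(Nc1cccc(-n2cc(-c3ccncc3)c(-c3cc(O)cc(Cl)c3)n2)c1)Nc1ccc(Cl)c(C(F)(F)F)c1`, 15.1%
compound 2, `COc1cc(Cl)cc(-c2nn(-c3cccc(NC(=O)Nc4ccc(Cl)c(C(F)(F)F)c4)c3)cc2-c2ccncc2)c1`, 9.1%
compound 3, `COc1cc(Cl)cc(-c2nn(-c3cccc(NC(=O)Nc4cc(C(F)(F)F)cc(C(F)(F)F)c4)c3)cc2-c2ccncc2)c1`, 12.2%

The three compounds share one core and were all tested in a functional assay on KM12 cells (Homo sapiens) for inhibition, read by sulforhodamine B assay, with a stated time of 48 h, tested at 10 uM; a higher number here means a weaker effect of the compound at the concentration tested, a lower number a stronger effect. Compound 2 gives the lowest of the three numbers, but its nearest neighbour is compound 3 and its furthest is compound 1, and both gaps lie within the scatter, so the three compounds cannot be ordered by these numbers. Going by the values given here, the only step between two compounds that differ in one place is a number 6 percentage points lower from compound 1 to compound 2 (within the scatter), a change of methyl in place of hydrogen on an oxygen on an aromatic ring, which lies within the scatter.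

Compound 4, `COc1cc(Cl)cc(-c2nn(-c3cccc(NC(=O)Nc4cccc(C(F)(F)F)c4)c3)cc2-c2ccncc2)c1`, has not yet been measured in this assay . It differs from compound 2 in one place: hydrogen in place of chloro on an aromatic carbon. Among the compounds with values here, no measured step concerns a change of this kind, so nothing bears directly on it; the one measured step, from compound 1 to compound 2, shows only that a small change elsewhere on the core left the number within the scatter. Compound 4 is therefore expected to show no step beyond the scatter, a number 4.9 percentage points higher from compound 2 to compound 4 (within the scatter), and its value in this assay is estimated at 14%, between 4% and 32%.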

Compound 4, a percentage reported as activity, at one concentration (the size of the read-out at that concentration, not a potency): 9.81%
Estimate against measurement, compound 4: 4.2 percentage points above, within the range that was stated.
By their numbers in this assay, from the lowest: compounds 2, 4, 3 and 1 (each within the scatter of the next).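

In this assay, going from 4-chloro-3-(trifluoromethyl)phenyl to 3-(trifluoromethyl)phenyl gives a number 0.7 percentage points higher from compound 2 to compound 4 (within the scatter), so at this carbon, ortho to the trifluoromethyl group and para to a large group, hydrogen and chloro cannot be told apart by this read-out at this concentration. The other change on this ring, hydrogen in place of trifluoromethyl, gives a number 2.4 percentage points lower from compound 3 to compound 4 (within the scatter), so neither change moves the number beyond the scatter. Nothing available explains this outcome.

On these data alone, what remains open is whether a group of another kind on this carbon, such as an amine, a carboxylic acid or a longer alkoxy chain, would leave the number where it is. A single concentration also cannot show whether compound 2 and compound 4 differ in potency.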